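From Trifluoromethoxyphenyl to Difluorophenyl in a Cytotoxicity Series

This account rests on a few compounds, and the source may have more. Where it says the series, first, only, none or still open, it means among the compounds named here.

Of the compounds shown here, three sharing one core have been tested in a functional assay on B16 cells (Mus musculus) for cytotoxicity, read by MTT assay, with a stated time of 72 h; a lower number here means a stronger inhibitor, a higher number a weaker inhibitor. Compound 1 `COc1cccc(/C=C/C(=O)Nc2cc(C(=O)c3cc(OC)c(OC)c(OC)c3)ccc2OC)c1` gives 3100 nM in this assay. Compound 2 `COc1ccc(C(=O)c2cc(OC)c(OC)c(OC)c2)cc1NC(=O)/C=C/c1ccc(C(F)(F)F)cc1` gives 100 nM, and compound 3 `COc1ccc(C(=O)c2cc(OC)c(OC)c(OC)c2)cc1NC(=O)/C=C/c1cccc(OC(F)(F)F)c1` gives 6300 nM. Compound 3 stands highest of the three numbers; its nearest neighbour is compound 1, and the furthest is compound 2. The measured steps are a 31-fold lower number from compound 1 to compound 2 (1.49 log units; beyond the scatter), a 2.0-fold higher number from compound 1 to compound 3 (0.31 log units; beyond the scatter) and a 63-fold higher number from compound 2 to compound 3 (1.80 log units; beyond the scatter).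

Compound 4 `COc1ccc(C(=O)c2cc(OC)c(OC)c(OC)c2)cc1NC(=O)/C=C/c1ccc(F)c(F)c1` differs from compound 3 in one place: 3,4-difluorophenyl in place of 3-(trifluoromethoxy)phenyl on a double-bonded chain carbon bound to a double-bonded chain carbon. Among the measured compounds shown here, no measured step swaps the aryl group for a 3,4-difluorophenyl, so the step from compound 3 to compound 4 has to be judged from the three steps above. Both compound 1 and compound 3, carrying 3-methoxyphenyl and 3-(trifluoromethoxy)phenyl, sit at high numbers, while compound 2 with 4-(trifluoromethyl)phenyl sits far lower, showing that a change of this aryl group can move the number by a large amount in either direction. Compound 4 is therefore expected to give a lower number than compound 3, with the step estimated as a 7.9-fold lower number from compound 3 to compound 4 (0.90 log units; beyond the scatter). Compound 4 is estimated at 800 nM in this assay, within a range from 150 nM to 5000 nM.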

Compound 4, half-maximal inhibitory concentration: 6500 nM
For compound 4 the middle estimate is 8.1-fold (0.91 log units) below the measured one, and the stated range ends below it.
By their numbers in this assay, from the lowest: compound 2; then compound 1; then compounds 3 and 4 (each within the scatter of the next).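

In this assay, a 1.0-fold higher number from compound 3 to compound 4 (0.01 log units; within the scatter) shows that at this position, on a double-bonded chain carbon bound to a double-bonded chain carbon, two different aryl groups can read alike: 3-(trifluoromethoxy)phenyl, with 11 heavy atoms and 1 hydrogen-bond acceptor, and 3,4-difluorophenyl, with 8 heavy atoms and 0 hydrogen-bond acceptors. The other two steps place the new compound in the series: a 65-fold higher number from compound 2 to compound 4 (1.81 log units; beyond the scatter) is a large gap, while a 2.1-fold higher number from compound 1 to compound 4 (0.32 log units; beyond the scatter) is only modest, so among the four aryl groups the low number stays with the 4-(trifluoromethyl)phenyl of compound 2 alone, and compound 4 joins compound 1 and compound 3 at the high end. No measurement is available here that bears on why these aryl groups read as they do.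

The compounds shown leave open whether the low number of compound 2 goes with the trifluoromethyl group as such or only with the 4-(trifluoromethyl)phenyl as a whole. They also leave open how this position would respond to an aryl group carrying an amine or a carboxylic acid, since every aryl group here bears only methoxy, trifluoromethoxy, trifluoromethyl or fluorine.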